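The source may hold more compounds than are shown below. What is called first, only, known or untested is meant among the compounds shown, and "the series" means these compounds.

The measured compounds:
Compound 1, `Cc1ccc(C2C(C#N)=C(N)N(c3ccc(S(N)(=O)=O)cc3)C3=C2CCCC3)cc1`, in a functional assay on Ehrlich cells (Mus musculus) for cytotoxicity, read by trypan blue exclusion, with a stated time of 2 h, tested at 100 ug/mL (on this read-out higher numbers stand for a stronger effect at the one concentration tested and lower numbers for a weaker effect), gives 90%.
Compound 2, `N#CC1=C(N)N(c2ccc(S(N)(=O)=O)cc2)C2=C(CCCC2)C1c1ccccc1O`, in this assay gives 100%.
Compound 3, `N#CC1=C(N)N(c2ccc(S(N)(=O)=O)cc2)C2=C(CCCC2)C1c1ccc(O)cc1`, in this assay gives 100%.

Compound 2 stands level with compound 3 at the digits reported, the two together forming the highest of the three numbers. Its nearest neighbour is compound 3: no change at the digits printed from compound 2 to compound 3 (within the scatter). Its furthest is compound 1: a number 10 percentage points higher from compound 1 to compound 2 (within the scatter). The step of interest leads to compound 4, `N#CC1=C(N)N(c2ccc(S(N)(=O)=O)cc2)C2=C(CCCC2)C1c1ccc([N+](=O)[O-])cc1`, not yet measured in this assay. The change is 4-nitrophenyl in place of 2-hydroxyphenyl on a saturated ring carbon. Going by the values given here, no measured step involves a nitro group, so the known steps bear on this one only indirectly. no change at the digits printed from compound 2 to compound 3 (within the scatter) shows that exchanging one hydroxyphenyl for the other on the saturated ring carbon left the number unchanged, and a number 10 percentage points higher from compound 1 to compound 3 (within the scatter) shows that exchanging methyl for hydroxy on the aromatic carbon also stayed within the scatter. Every aryl group tried so far gives a high read-out in this assay. Compound 4 is therefore expected to remain high as well, with a number 10 percentage points lower from compound 2 to compound 4 (within the scatter), a step not expected to exceed the scatter. The estimate for compound 4 is 90%, within 70% to 100%.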

Compound 4, a percentage reported as activity, at one concentration (the size of the read-out at that concentration, not a potency): 20%
Compound 4: the middle estimate sits 70 percentage points above what was measured; the measured number lies below the stated range.
By their numbers in this assay, from the lowest: compound 4; then compounds 1, 2 and 3 (each within the scatter of the next).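

In this assay, putting 4-nitrophenyl in place of 2-hydroxyphenyl on the saturated ring carbon gives a number 80 percentage points lower from compound 2 to compound 4 (beyond the scatter), nitro in place of hydroxy on the aromatic carbon gives a number 80 percentage points lower from compound 3 to compound 4 (beyond the scatter), and nitro in place of methyl on that carbon gives a number 70 percentage points lower from compound 1 to compound 4 (beyond the scatter). Going by these compounds alone, the earlier exchanges of methyl, hydroxy and the two hydroxyphenyl groups all stayed within the scatter, so this is the first change at this position to move the read-out beyond it, and the high read-out does not hold for every aryl group on this carbon: compound 4 stands apart from compounds 1, 2 and 3. The data shown contain no measurement that accounts for this drop.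

From the compounds shown here alone, it remains open whether the loss is specific to the nitro group or would also appear with another group on that aromatic carbon, such as an amine, a carboxylic acid or a methoxy group. Also open, going by these compounds, is how compound 4 would read at other concentrations, as a reading at one concentration is not a potency.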